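A second bromo on compound 2

The source may hold more compounds than are shown below. What is called first, only, known or untested is meant among the compounds shown, and "the series" means these compounds.

In a functional assay on T29Kt1 cells (Homo sapiens) for cytotoxicity, read by sulforhodamine B assay, with a stated time of 3 days (on this read-out lower numbers stand for stronger inhibition and higher numbers for weaker inhibition), compound 1 `OCc1cn(Cc2cccc(F)c2)c2ccccc12` gives 20 nM and compound 2 `OCc1cn(Cc2cccc(Br)c2)c2ccccc12` gives 32 nM while compound 3 `Cc1cccc(Cn2cc(CO)c3ccccc32)c1` gives 1000 nM by contrast. Compound 2 therefore sits with compound 1 at the low end and far from compound 3. Compound 4 `OCc1cn(Cc2ccc(Br)c(Br)c2)c2ccccc12` carries the change bromo in place of hydrogen on an aromatic carbon as bromo in place of hydrogen, ortho to a bromo group. The exchange of halogens is a 1.6-fold higher number from compound 1 to compound 2 (0.20 log units; within the scatter) as a step, whereas the methyl exchanges are a 50-fold higher number from compound 1 to compound 3 (1.70 log units; beyond the scatter) and a 31-fold higher number from compound 2 to compound 3 (1.49 log units; beyond the scatter) in size. None of these steps replaces hydrogen, so they guide the expectation only loosely. A small upward move is expected, namely a 1.6-fold higher number from compound 2 to compound 4 (0.19 log units; within the scatter) in size. For compound 4 the estimate is 50 nM with an expected range from 12 nM to 250 nM around it.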

Compound 4, half-maximal inhibitory concentration: 100 nM
Compound 4: the middle estimate sits 2.0-fold (0.30 log units) below what was measured; low and high end bracket the measured number.
By their numbers in this assay, from the lowest: compounds 1 and 2 (each within the scatter of the next); then compound 4; then compound 3.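

The added bromo, ortho to a bromo group and para to a large group, raises the number beyond the scatter, a 3.1-fold higher number from compound 2 to compound 4 (0.49 log units; beyond the scatter), so this aromatic carbon does not take the new group without a modest loss. It is the only step shown that replaces hydrogen rather than exchanging one group for another. No measurement at hand bears on why the number rises.

Bromo is the only group shown at this carbon, so whether the loss belongs to bromo or to any group there stays open. A methoxy or an amine at the same place would separate these two readings.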